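Sulfonyl substitution in the benzoxazole sulfonamide series: methyl for 2-chlorophenyl

The source may report more compounds than this note shows. Statements on the series, on what has been measured and on what is new or still open speak of the compounds shown alone.

Working notes. The series is benzoxazole sulfonamides tested in an assay on cells for inhibition of HSP60/HSP10 (Homo sapiens), with a stated time of 60 min; a lower number here means a stronger inhibitor, a higher number a weaker inhibitor. Compound 1 `CS(=O)(=O)Nc1ccc(-c2nc3cc(NS(=O)(=O)c4ccc(Cl)s4)ccc3o2)cc1` gives 43000 nM. Compound 2 `O=S(=O)(Nc1ccc2oc(-c3ccccc3)nc2c1)c1ccccc1Cl` gives only a limit of the assay, > 100000 nM. Compound 3 `O=S(=O)(Nc1ccc(-c2nc3ccccc3o2)cc1)c1ccccc1O` likewise returns a limit, > 100000 nM. Compound 2 therefore stands at the weak end of what has been seen, with no number at all, and it is not alone there: the limit of > 100000 nM in this assay, at which 2 of the 3 values shown sit. Only compound 1 yields a numerical value, and that one is itself weak.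

The step under consideration moves from compound 2 to compound 4 `CS(=O)(=O)Nc1ccc2oc(-c3ccccc3)nc2c1`. The change is methyl in place of 2-chlorophenyl on a sulfonyl sulfur. Among the compounds with values here, no pair of measured compounds in the set differs in one place only, so there is no measured step to lean on in this assay . Given that compound 2 is already at the limit, the shift from compound 2 to compound 4 is expected to be none beyond the scatter, with compound 4 most likely also returning a limit rather than a number: a step that the limit leaves unreadable from compound 2 to compound 4.

Compound 4 is thus estimated at 150000 nM, within 60000 nM to 400000 nM, in this assay .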

Compound 4, half-maximal inhibitory concentration: > 100000 nM
Compound 4: only a limit was reported; the forecaster's own chance of this, stated with the estimate: 80%; the middle value does not contradict the limit.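

In this assay compound 4 returns > 100000 nM, which is a limit of the assay. No step can be read between compound 2 and compound 4, as both carry only a limit: the limit of > 100000 nM in this assay, at which 3 of the 4 values shown sit. The compounds shown leave open whether methyl in place of 2-chlorophenyl on a sulfonyl sulfur changes inhibition at all.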